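Morpholine Amide Replacing the Anilide in a Nitrobenzofurazan Series

The source may report more compounds than this note shows. Statements on the series, on what has been measured and on what is new or still open speak of the compounds shown alone.

Measured compounds in an assay on isolated protein for inhibition of glutathione S-transferase Mu 2 (Homo sapiens), with a stated time of 10 min; a higher number here means a weaker inhibitor, a lower number a stronger inhibitor:
- compound 1 `O=C(CCC(=O)OCCCCCCSc1ccc([N+](=O)[O-])c2nonc12)Nc1cccc(Cl)c1` gives 1100 nM
- compound 2 `Cc1ccc(NC(=O)CCC(=O)OCCCCCCSc2ccc([N+](=O)[O-])c3nonc23)cc1` gives 390 nM
- compound 3 `CN(C)CCCNC(=O)CCC(=O)OCCCCCCSc1ccc([N+](=O)[O-])c2nonc12` gives 90 nM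

Compound 1 has the highest number of the three. Its nearest neighbour is compound 2, with a 2.8-fold lower number from compound 1 to compound 2 (0.45 log units; beyond the scatter); the furthest is compound 3, with a 12-fold lower number from compound 1 to compound 3 (1.09 log units; beyond the scatter). Between them lies a 4.3-fold lower number from compound 2 to compound 3 (0.64 log units; beyond the scatter).

Compound 4 `O=C(CCC(=O)N1CCOCC1)OCCCCCCSc1ccc([N+](=O)[O-])c2nonc12` has not yet been measured in this assay. It differs from compound 1 in one place: morpholin-4-yl in place of (3-chlorophenyl)amino on a carbonyl carbon. The step from compound 1 to compound 3 bears most on this change, as the aromatic ring on the amide-type nitrogen there also gives way to a non-aromatic group, and the step from compound 1 to compound 2 adds a smaller change in the same direction. On that basis a lower number is expected for compound 4, estimated at 250 nM (range 80 nM to 800 nM), meaning an expected step of a 4.4-fold lower number from compound 1 to compound 4 (0.64 log units; beyond the scatter).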

Compound 4, half-maximal inhibitory concentration: 170 nM
For compound 4 the middle estimate is 1.5-fold (0.17 log units) above the measured one, within the range that was stated.
By their numbers in this assay, from the lowest: compounds 3 and 4 (each within the scatter of the next); then compound 2; then compound 1.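

In this assay morpholin-4-yl gives a 6.5-fold lower number from compound 1 to compound 4 (0.81 log units; beyond the scatter) and a 2.3-fold lower number from compound 2 to compound 4 (0.36 log units; beyond the scatter) on this carbonyl carbon, so among these compounds neither an aromatic ring nor the amide hydrogen is required here. Compound 4 also lacks the side-chain dimethylamino group of compound 3, yet the comparison gives a 1.9-fold higher number from compound 3 to compound 4 (0.28 log units; within the scatter) and so separates the two by no more than the usual scatter. Nothing at hand accounts for these steps. The compounds shown leave open whether the morpholine ring oxygen matters, as piperidin-1-yl at this carbon would show, and how a carboxylic acid would fare there.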